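Hydroxy to methyl on a cyclic scaffold: one predicted value

The source may report more compounds than this note shows. Statements on the series, on what has been measured and on what is new or still open speak of the compounds shown alone.

Compounds measured so far:
compound 1, `CC(C)C[C@@H]1NC(=O)[C@H](CC(C)C)NC(=O)[C@H](CC(C)C)NC(=O)[C@@H](Cc2c[nH]c3ccccc23)NC(=O)[C@H](CC(C)C)NC1=O`, gives 18%;
compound 2, `CC(C)C[C@@H]1NC(=O)[C@H](Cc2ccccc2)NC(=O)[C@H](CC(C)C)NC(=O)[C@@H](C(C)C)NC(=O)[C@H](CCCCN)NC1=O`, gives 20%;
compound 3, `CC(C)C[C@@H]1NC(=O)[C@H](Cc2ccccc2)NC(=O)[C@H](CC(C)C)NC(=O)[C@@H](CO)NC(=O)[C@H](CC(C)C)NC1=O`, gives 25%.

All three were tested in a functional assay on PL45 cells (Homo sapiens) for inhibition, tested at 5 uM (a higher number here means more inhibition at the concentration tested (going by the name of the read-out), a lower number less inhibition), where compound 3 shows 25%. Its number sits within the usual scatter of those of compound 2 and compound 1, so the three cannot be told apart on this read-out; none of them stands out from the others.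

Compound 4, `CC[C@H]1NC(=O)[C@H](CC(C)C)NC(=O)[C@H](CC(C)C)NC(=O)[C@H](Cc2ccccc2)NC(=O)[C@H](CC(C)C)NC1=O`, has not yet been measured. It differs from compound 3 in a single place: methyl in place of hydroxy on a saturated chain carbon bound to a saturated ring carbon. Among the measured compounds shown here, no pair of measured compounds differs in just one place, so there is no measured step that shows how such an exchange moves the number in this assay. The three values that exist are close to one another despite larger differences between the structures, which suggests that a change of one heavy atom is unlikely to move the read-out beyond the scatter in either direction.

For compound 4 the expected step is a number 3 percentage points lower from compound 3 to compound 4 (within the scatter), essentially no change. Compound 4 is therefore estimated at 22%, with a range from 8% to 38%.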

Compound 4, a percentage reported as inhibition, at one concentration (the size of the read-out at that concentration, not a potency): 12%
Estimate against measurement, compound 4: 10 percentage points above; the measured number falls inside the stated range.
By their numbers in this assay, from the lowest: compounds 4, 1, 2 and 3 (each within the scatter of the next, the first and the last beyond it).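

In this assay, among the compounds shown here, the exchange gives a number 13 percentage points lower from compound 3 to compound 4 (beyond the scatter), the only step here between compounds that differ in one place. It shows that the group on this saturated chain carbon bound to a saturated ring carbon is not indifferent to the read-out, even though the change swaps one heavy atom for one heavy atom and leaves the net charge untouched. Read one bond further out, hydroxymethyl gives way to ethyl, and the hydrogen-bond donor and acceptor counted for hydroxy are absent from methyl, but no measurement here connects that difference to the lower number.

On these data alone, it remains open whether an amine, a carboxylic acid or a methoxy group at this place would keep the number of compound 3, lower it like methyl, or raise it, and whether a longer chain such as propyl would go further in the direction of ethyl. This single pair also cannot tell whether the same exchange would move the number in the same way on another member of the series.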